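From Methylamino to Butylamino: Compound 3 to Compound 4

The compounds below may be only part of what the source reports. "The series", "measured", "known", "first", "only" and "open" are said of these compounds alone.

- compound 1 `CCOC(=O)c1ccc(S(N)(=O)=O)cc1` measured at 1.17
- compound 2 `CCCOC(=O)c1ccc(S(N)(=O)=O)cc1` measured at 1.75
- compound 3 `CNC(=O)c1ccc(S(N)(=O)=O)cc1` measured at -0.31
- compound 4 `CCCCNC(=O)c1ccc(S(N)(=O)=O)cc1` not yet measured

In a physicochemical assay for lipophilicity (on this read-out higher numbers stand for higher lipophilicity and lower numbers for lower lipophilicity), compound 3 stands lowest of the three measured compounds. The change to compound 4 is propyl in place of hydrogen on a saturated chain carbon bound to an amide-type nitrogen that is, propyl in place of hydrogen on a saturated chain carbon bound to an amide-type nitrogen, which turns methylamino into butylamino.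

Among the measured compounds shown here, no measured step makes this exact change. The closest guide is a number 0.58 log units higher from compound 1 to compound 2 (beyond the scatter) where methyl replaces hydrogen on a saturated chain carbon elsewhere in the molecule. The large steps, a number 1.48 log units lower from compound 1 to compound 3 (beyond the scatter) and a number 2.06 log units lower from compound 2 to compound 3 (beyond the scatter) swap the whole group on the carbonyl carbon, so they say less about growing a chain. Propyl is a longer addition than that single methyl, so a larger upward move than the modest one from compound 1 to compound 2 seems likely. The expected result is a number 1.61 log units higher from compound 3 to compound 4 (beyond the scatter) in this assay on this reasoning. Compound 4 is estimated at 1.3 within an expected range of 0.8 to 1.8 on this scale.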

Compound 4, partition coefficient: 1.05
Compound 4: the middle estimate sits 0.25 log units above what was measured, within the range that was stated.
By their numbers in this assay, from the lowest: compound 3; then compounds 4 and 1 (each within the scatter of the next); then compound 2.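

In this assay, propyl in place of hydrogen on a saturated chain carbon bound to an amide-type nitrogen gives a number 1.36 log units higher from compound 3 to compound 4 (beyond the scatter), the first measured chain growth on the amide side of these compounds, and it shows that this position responds strongly to that change. Exchanging ethoxy for butylamino gives a number 0.12 log units lower from compound 1 to compound 4 (within the scatter), so the longer amide chain removes any clear gap to the ethoxy compound, while butylamino in place of propoxy still gives a number 0.70 log units lower from compound 2 to compound 4 (beyond the scatter). Nothing available here accounts for these shifts.

Ethylamino and propylamino would show whether the rise builds evenly along the chain, and hexylamino whether it continues. Going by these compounds, what an amine or a carboxylic acid would give on a saturated chain carbon bound to an amide-type nitrogen also remains open.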